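This account rests on a few compounds, and the source may have more. Where it says the series, first, only, none or still open, it means among the compounds named here.

Series on the shared core of compound 1 `CCOC(=O)C(C)C(O)(c1ccc(OC)c(OC)c1OC)c1cccc2ccccc12`, varied at the saturated chain carbon bound to two aromatic carbons and an oxygen on a saturated carbon. In a functional assay on MDA-MB-231 cells (Homo sapiens) for inhibition, read by sulforhodamine B assay, with a stated time of 48 h (a lower number here means a stronger inhibitor, a higher number a weaker inhibitor), compound 1 gives only a limit, > 20000 nM (the limit of > 20000 nM in this assay, at which 1 of the 3 values shown sits). Compound 2 `COc1ccc(C(O)(Cc2ccc(F)cc2)c2cccc3ccccc23)c(OC)c1OC` gives 5440 nM in this assay and compound 3 `COc1ccc(C(O)(Cc2ccccc2)c2cccc3ccccc23)c(OC)c1OC` gives 4780 nM; the two numbers sit within the scatter of each other, as a 1.1-fold lower number from compound 2 to compound 3 (0.06 log units; within the scatter) shows, so neither stands apart. Among the measured compounds shown here, the only steps reaching beyond the scatter are an at least 3.6-fold lower number from compound 1 to compound 2 (0.56 log units; beyond the scatter) and an at least 4.1-fold lower number from compound 1 to compound 3 (0.62 log units; beyond the scatter). Compound 4 `C=CCC(O)(c1ccc(OC)c(OC)c1OC)c1cccc2ccccc12` differs from compound 3 by vinyl in place of phenyl on a saturated chain carbon, two bonds along the chain from two aromatic carbons and an oxygen on a saturated carbon. For the measured compounds named here, no measured step removes the aromatic ring from this chain, so the measured steps bear only indirectly; a move back toward compound 1 is possible. Compound 4 is expected at 9000 nM, between 3000 nM and 25000 nM, an expected step of a 1.9-fold higher number from compound 3 to compound 4 (0.27 log units; within the scatter).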

Compound 4, half-maximal inhibitory concentration: > 20000 nM
Compound 4: a limit, no number; the forecaster's own chance of this, stated with the estimate: 25%; middle value at least 2.2-fold (0.34 log units) away from the limit.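

In this assay, vinyl in place of phenyl gives an at least 4.1-fold higher number from compound 3 to compound 4 (0.62 log units; beyond the scatter), and vinyl in place of 4-fluorophenyl gives an at least 3.6-fold higher number from compound 2 to compound 4 (0.56 log units; beyond the scatter). At this position, then, the aromatic ring on the chain matters: the benzyl and 4-fluorobenzyl compounds give numbers, while the allyl compound does not. Compound 4 gives only a limit, not a number: the limit of > 20000 nM in this assay, at which 2 of the 4 values shown sit.

The step between compound 1 and compound 4 cannot be read, as both are limits. From the compounds shown here alone, whether a longer chain ending in phenyl, or an amine on the chain, holds the activity of the benzyl compounds stays open.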